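The source may hold more compounds than are shown below. What is called first, only, known or untested is meant among the compounds shown, and "the series" means these compounds.

Compound 1, `CN1CCN(CCCCCCn2c3c(c4ccccc42)C(=O)c2c[n+]([O-])c4ccccc4c2C3=O)CC1`, gives 400 nM in a functional assay on MCF7 cells (Homo sapiens) for cytotoxicity, read by MTT assay, with a stated time of 72 h; a higher number here means a weaker inhibitor, a lower number a stronger inhibitor.
Compound 2, `CN1CCN(CCCCCn2c3c(c4ccccc42)C(=O)c2c[n+]([O-])c4ccccc4c2C3=O)CC1`, gives 1260 nM.
Compound 3, `CN(C)CCCCn1c2c(c3ccccc31)C(=O)c1c[n+]([O-])c3ccccc3c1C2=O`, gives 220 nM.

Among these three, compound 3 carries the lowest number, but its gap to compound 1 is within the usual scatter, so the two cannot be ranked against each other; only compound 2 sits clearly apart, as seen in a 5.7-fold lower number from compound 2 to compound 3 (0.76 log units; beyond the scatter). The next compound, compound 4, `CN(C)CCCCCn1c2c(c3ccccc31)C(=O)c1c[n+]([O-])c3ccccc3c1C2=O`, is reached from compound 3 by a single change: (dimethylamino)methyl in place of dimethylamino on a saturated chain carbon, four bonds along the chain from an aromatic nitrogen. In plain terms the chain between the aromatic nitrogen and the amine grows by one carbon while the amine itself stays the same.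

One measured step speaks to this kind of change. Going from compound 1 to compound 2 the chain was shortened by one carbon with the methylpiperazine in place, and the number rose: a 3.2-fold higher number from compound 1 to compound 2 (0.50 log units; beyond the scatter). Read in reverse, adding a carbon to that chain brought the number down. The step of a 1.8-fold lower number from compound 1 to compound 3 (0.26 log units; within the scatter) swaps both chain and amine at once and stays within the scatter, so it adds little guidance. Within the data shown here, with only one informative step, the expectation for compound 4 is a modest drop or no change beyond the scatter, a 1.5-fold lower number from compound 3 to compound 4 (0.17 log units; within the scatter). Compound 4 is therefore estimated at 150 nM, within a range of 60 nM to 450 nM.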

Compound 4, half-maximal inhibitory concentration: 200 nM
Beside the measured number, compound 4's estimate is 1.3-fold (0.12 log units) below it; the measured number falls inside the stated range.
By their numbers in this assay, from the lowest: compounds 4, 3 and 1 (each within the scatter of the next); then compound 2.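

With dimethylamino at its end, adding one carbon to the chain brings no readable change, a 1.1-fold lower number from compound 3 to compound 4 (0.04 log units; within the scatter), whereas the chain pair carrying the 4-methylpiperazin-1-yl end did separate, a 3.2-fold higher number from compound 1 to compound 2 (0.50 log units; beyond the scatter), so the chain-length trend seen there does not carry over to the dimethylamino pair. Among these compounds, the new compound also gives the first comparison of the two amines on an identical chain: putting dimethylamino in place of 4-methylpiperazin-1-yl gives a 6.3-fold lower number from compound 2 to compound 4 (0.80 log units; beyond the scatter), a clear step, while the swap of dimethylamino for (4-methylpiperazin-1-yl)methyl on the longer chain gives only a 2.0-fold lower number from compound 1 to compound 4 (0.30 log units; within the scatter). What an amine swap does here therefore depends on the chain that carries it, and the size of the step is not fixed: the same change on two cores in this assay, a 5.7-fold lower number (0.76 log units; beyond the scatter) from compound 2 to compound 3 and a 2.0-fold lower number (0.30 log units; within the scatter) from compound 1 to compound 4, 2.9-fold (0.46 log units) apart, beyond the scatter of two such steps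

Among the compounds shown, only two amine ends appear, so it remains open whether a morpholine or piperidine end would respond to chain length as dimethylamino does or as 4-methylpiperazin-1-yl does. A shorter 3-(dimethylamino)propyl chain or a longer 6-(dimethylamino)hexyl chain would show whether the flat dimethylamino pair holds beyond these two lengths.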